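The compounds below may be only part of what the source reports. "The series", "measured", "known", "first", "only" and "open" are said of these compounds alone.

Compounds measured in an assay on isolated protein for inhibition of proto-oncogene tyrosine-protein kinase receptor Ret variant V804L (Homo sapiens), read by 33P incorporation, with stated times of 15 min and 40 min; a lower number here means a stronger inhibitor, a higher number a weaker inhibitor:
compound 1 `CC(C)(C)c1cc(NC(=O)Nc2ccc(Nc3ncnc4c3OCCN4)c(F)c2)no1` gives 27 nM
compound 2 `COc1cc(NC(=O)Nc2cc(C(C)(C)C)on2)ccc1Nc1ncnc2c1OCCN2` gives 29 nM

Among the measured compounds shown here, compound 2 holds the higher of the two numbers, yet its nearest neighbour is compound 1, and the only measured step, a 1.1-fold higher number from compound 1 to compound 2 (0.03 log units; within the scatter), stays within the scatter, so the two compounds cannot be ordered on these data.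

Compound 3 `CC(C)(C)c1cc(NC(=O)Nc2ccc(Nc3ncnc4c3OCCN4)c(O)c2)no1` is not yet measured. It differs from compound 2 by hydrogen in place of methyl on an oxygen on an aromatic ring. For the measured compounds named here, no measured step changes a methyl on an oxygen on an aromatic ring, so nothing bears on this change directly; the one step available, a 1.1-fold higher number from compound 1 to compound 2 (0.03 log units; within the scatter), only shows that swapping the group at this position between fluoro and methoxy left this assay unchanged within the scatter. On that basis no step beyond the scatter is expected, and the estimated step is a 1.2-fold higher number from compound 2 to compound 3 (0.08 log units; within the scatter). Compound 3 is therefore estimated at 35 nM, with a range of 12 nM to 100 nM.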

Compound 3, half-maximal inhibitory concentration: 163 nM
Compound 3: middle estimate off by 4.7-fold (0.67 log units), on the low side; the measured number lies above the stated range.
By their numbers in this assay, from the lowest: compounds 1 and 2 (each within the scatter of the next); then compound 3.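

In this assay the group on this aromatic carbon does make a difference: hydrogen in place of methyl on the oxygen gives a 5.6-fold higher number from compound 2 to compound 3 (0.75 log units; beyond the scatter) and hydroxy in place of fluoro gives a 6.0-fold higher number from compound 1 to compound 3 (0.78 log units; beyond the scatter), whereas the earlier swap between fluoro and methoxy stayed within the scatter. Both steps point the same way, so among these three compounds hydroxy is the one group that separates from the others, and the methyl on the oxygen cannot be removed without a change in this read-out. Nothing available gives a reason for this step.

As far as these compounds go, whether an amine, an ethoxy group or a plain hydrogen on this aromatic carbon would stay with fluoro and methoxy or fall with hydroxy remains open. A single hydroxy compound also leaves open whether the step holds when other parts of the molecule change.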